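Working notes: maximal response across a shared-core series

This account rests on a few compounds, and the source may have more. Where it says the series, first, only, none or still open, it means among the compounds named here.

Measured so far:
- compound 1 `C[C@H]1CN(c2ncc(OCc3ccc(S(C)(=O)=O)cc3)cn2)CCN1C(=O)OC(C)(C)C`: 163%
- compound 2 `C[C@@H]1CN(C(=O)OC(C)(C)C)CCN1c1ncc(OCc2ccc(S(=O)(=O)N(C)C)cc2)cn1`: 66%

Both compounds share the same core and differ only in the group carried on the benzyl ether. In an in vitro functional assay on HEK293S cells with Glucose-dependent insulinotropic receptor (Homo sapiens) as the target, read by HTRF and cAMP accumulation, with a stated time of 45 min (on this read-out lower numbers stand for smaller maximal responses and higher numbers for larger maximal responses), compound 1 gives 163%, whereas compound 2 gives 66%. Compound 2 therefore stands lowest of the two numbers, and the gap to compound 1 lies well beyond the usual scatter of this assay.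

Compound 3 `C[C@@H]1CN(C(=O)OC(C)(C)C)CCN1c1ncc(OCc2ccc(-n3cnnn3)cc2)cn1` is not yet measured. It differs from compound 2 in one place: 1H-tetrazol-1-yl in place of dimethylsulfamoyl on an aromatic carbon. The dimethylsulfamoyl group leaves and 1H-tetrazol-1-yl enters on the same aromatic carbon of the carbon-only six-membered ring.

Within the data shown here, no measured pair shows this particular exchange, so the two values available give no direct guide to its size or direction. Given that the single recorded exchange at this position moved the maximal response strongly, a step beyond the scatter is expected in this assay from compound 2 to compound 3, most likely upward, as a number 34 percentage points higher from compound 2 to compound 3 (beyond the scatter). Compound 3 is estimated at 100%, with a range from 50% to 165%.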

Compound 3, intrinsic activity: the largest response reached, in percent of the reference agonist's: 89%
For compound 3 the middle estimate is 11 percentage points above the measured one; the measured number falls inside the stated range.
By their numbers in this assay, from the lowest: compound 2; then compound 3; then compound 1.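

In this assay, among these compounds, placing 1H-tetrazol-1-yl instead of dimethylsulfamoyl on the aromatic carbon para to a large group gives a number 23 percentage points higher from compound 2 to compound 3 (beyond the scatter) and is the first single-place change that can be read. It shows that the maximal response depends on the group at this position, and that a group with no ring can be replaced by a five-membered aromatic ring with 4 hetero atoms without a loss of response. Nothing at hand bears on why the response moves with this exchange.

The compounds shown leave open whether this gain is particular to 1H-tetrazol-1-yl or would also appear with another group on the same aromatic carbon, such as a carboxylic acid, a primary amide or a simple amine. Also open, going by these compounds, is whether the same exchange gives a step of similar size and direction on the core of compound 1.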